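Benzyl ether series: cytotoxicity notes and one estimate

A few compounds are considered here, and "the series" means these few. Any claim that something is new, unique, unknown or untested is made for them only; others in the source may bear on it.

Measured so far:
compound 1 `CC(C)(C)OC(=O)Nc1ncc(C(Oc2ccc(OCc3ccccc3)cc2)c2ccc(Cl)cc2)s1` gives > 50000 nM
compound 2 `O=C(Nc1ncc(C(OCc2ccc(Br)cc2)c2ccccc2)s1)c1cccs1` gives "not toxic" (no number reported)
compound 3 `Cc1ccc(COC(c2ccccc2)c2cnc(NC(=O)c3cccs3)s2)cc1` gives "not toxic" (no number reported)

In an ADME assay on HepG2 2.2.15 cells (Homo sapiens) for cytotoxicity (a higher number here means that more compound is tolerated, a lower number that less compound is tolerated), compound 1 stops at a limit of the assay, > 50000 nM; this is the case the limit of > 50000 nM in this assay, at which 1 of the 3 values shown sits, records. Compound 2 is entered in this assay only as "not toxic" (no number reported), without a number. Compound 3 likewise carries only the entry "not toxic" (no number reported) in this assay. So compound 3 stands without a single number: of the three entries one is a limit and the other two are bare notes of no toxicity. Within the data shown here, no pair of measured compounds differs in one place, so no measured step in this assay exists, and nothing here ranks one compound against another.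

Compound 4 `O=C(Nc1ncc(C(OCc2ccc(F)cc2F)c2ccccc2)s1)c1cccs1` differs from compound 3 by 2,4-difluorophenyl in place of 4-methylphenyl on a saturated chain carbon bound to an oxygen on a saturated carbon. Without a measured step to lean on, the expectation in this assay is no movement beyond the usual scatter, and most likely again an entry at the limit rather than a number. Compound 4 is estimated at 50000 nM, with the expected range running from 20000 nM to 100000 nM.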

Compound 4, half-maximal cytotoxic concentration: "not toxic" (no number reported)
Compound 4 has no reported number here, and the estimate cannot be compared.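

No step can be read from compound 3 to compound 4: both are entered in this assay only as not toxic, without a number. From the compounds shown here alone, whether the change from 4-methylbenzyl to 2,4-difluorobenzyl shifts the tolerated concentration at all stays open, and the only figure on record for the series is a limit: the limit of > 50000 nM in this assay, at which 1 of the 4 values shown sits.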